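Changing the aryl ether of compound 3

The compounds below may be only part of what the source reports. "The series", "measured", "known", "first", "only" and "open" are said of these compounds alone.

Compound 1 `CC(C)[C@H](NC(=O)COc1cccc2ccccc12)C(=O)N[C@@H](CC(=O)O)C(=O)COc1ccc(-c2ccccc2)cc1`: 38700 nM
Compound 2 `CC(C)[C@H](NC(=O)COc1cccc2ccccc12)C(=O)N[C@@H](CC(=O)O)C(=O)COc1ccc(C#N)cc1`: 26700 nM
Compound 3 `CC(C)[C@H](NC(=O)COc1cccc2ccccc12)C(=O)N[C@@H](CC(=O)O)C(=O)COc1cc(F)cc(F)c1`: 15900 nM

In a functional assay with Homo sapiens as the target (a lower number here means a stronger inhibitor, a higher number a weaker inhibitor), compound 3 gives 15900 nM. That stands within the scatter of compound 2, with a 1.7-fold lower number from compound 2 to compound 3 (0.23 log units; within the scatter), and apart from compound 1, with a 2.4-fold lower number from compound 1 to compound 3 (0.39 log units; beyond the scatter). Compound 4 `CC(C)[C@H](NC(=O)COc1cccc2ccccc12)C(=O)N[C@@H](CC(=O)O)C(=O)COc1cccc(C(F)(F)F)c1F` carries 2-fluoro-3-(trifluoromethyl)phenyl in place of 3,5-difluorophenyl on an oxygen on a saturated carbon. All three measured steps alter the group at this place. Besides the two above, there is a 1.4-fold lower number from compound 1 to compound 2 (0.16 log units; within the scatter). Since these steps are small, no change beyond the scatter is expected in this assay. The expected step is a 1.1-fold higher number from compound 3 to compound 4 (0.05 log units; within the scatter). For compound 4 the estimate is 18000 nM, with an expected range of 8000 nM to 40000 nM.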

Compound 4, half-maximal inhibitory concentration: 18200 nM
Estimate against measurement, compound 4: 1.0-fold (0.00 log units) below, and the stated range covers the measured number.
By their numbers in this assay, from the lowest: compounds 3, 4, 2 and 1 (each within the scatter of the next, the first and the last beyond it).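

In this assay, the place on the oxygen takes 2-fluoro-3-(trifluoromethyl)phenyl, with more heavy atoms and more fluorine than 3,5-difluorophenyl, without a change beyond the scatter (a 1.1-fold higher number from compound 3 to compound 4 (0.06 log units; within the scatter)), and the same holds against 4-cyanophenyl (a 1.5-fold lower number from compound 2 to compound 4 (0.17 log units; within the scatter)). Only 4-phenylphenyl stays apart (a 2.1-fold lower number from compound 1 to compound 4 (0.33 log units; beyond the scatter)), as it did against 3,5-difluorophenyl. No evidence on a cause bears on this result. From the compounds shown here alone, what an amine or a carboxylic acid on the phenyl ring would give stays open, as does a plain alkyl chain in place of that ring.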